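Enlarging the amide substituent on the shared core

The compounds below may be only part of what the source reports. "The series", "measured", "known", "first", "only" and "open" are said of these compounds alone.

Of the compounds shown here, two built on one shared core have been measured in an assay on CHO-K1 cells for displacement of a labelled ligand from prostaglandin E2 receptor EP1 subtype (Homo sapiens); on this read-out lower numbers stand for stronger inhibition and higher numbers for weaker inhibition. Compound 1 `Cc1cc(C(=O)NC(C)C)nn1Cc1cc(Cl)ccc1OCc1ccccc1` gives 126 nM in this assay. Compound 2 `CC(=O)Nc1cc(C)n(Cc2cc(Cl)ccc2OCc2ccccc2)n1` gives 316 nM in this assay. The step between them reads a 2.5-fold higher number from compound 1 to compound 2 (0.40 log units; beyond the scatter), so compound 2 stands with the higher of the two numbers, and compound 1 sits a clear step lower, beyond the scatter.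

Compound 3 `Cc1cc(NC(=O)C2CCCC2)nn1Cc1cc(Cl)ccc1OCc1ccccc1` has not yet been measured. It differs from compound 2 in one place: cyclopentyl in place of methyl on a carbonyl carbon. Going by the values given here, no measured step makes this same change. Among the compounds with values here, the only step known, a 2.5-fold higher number from compound 1 to compound 2 (0.40 log units; beyond the scatter), exchanges the whole amide group for a different one, so it does not show directly how enlarging the group on the carbonyl carbon while keeping the acetamido-type linkage would read. For compound 3 the expected step is a 2.0-fold lower number from compound 2 to compound 3 (0.30 log units; within the scatter), a modest move toward a lower number, held with wide uncertainty. Compound 3 is therefore estimated at 160 nM in this assay, with a plausible range from 50 nM to 500 nM.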

Compound 3, half-maximal inhibitory concentration: 15.9 nM
Compound 3: middle estimate off by 10-fold (1.00 log units), on the high side, outside the stated range (below it).
By their numbers in this assay, from the lowest: compound 3; then compound 1; then compound 2.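

Going by these compounds alone, on the carbonyl carbon of the acetamido-type group, cyclopentyl in place of methyl brings a 20-fold lower number from compound 2 to compound 3 (1.30 log units; beyond the scatter) in this assay and so shows that this position responds strongly to the group it carries, which the single earlier step, an exchange of one whole amide group for another, could not show. The comparison with the other amide group also changes: (cyclopentylcarbonyl)amino in place of isopropylcarbamoyl brings a 7.9-fold lower number from compound 1 to compound 3 (0.90 log units; beyond the scatter) and puts compound 3 lowest of the three, whereas acetamido in that same place had given the higher number. Nothing available here explains why the larger group reads so much lower.

The compounds shown leave open whether the ring itself matters or simply the larger carbon group, which an open pentyl chain on the same carbonyl carbon could help to separate, and whether a cyclobutyl or cyclohexyl ring would read lower or higher than cyclopentyl. They also leave open whether cyclopentylcarbamoyl, which would place the same ring on the other amide group, would read as low as compound 3.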